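The source may report more compounds than this note shows. Statements on the series, on what has been measured and on what is new or still open speak of the compounds shown alone.

Among the measured compounds shown here, compound 1 `COc1cccc(/C=C2\CCc3cc(OC)c(OC)cc3C2=O)c1` is the only member of this small set with a number rather than a limit: in a functional assay on Jurkat cells (Homo sapiens) for antiproliferative activity, read by MTT assay (on this read-out lower numbers stand for stronger inhibition and higher numbers for weaker inhibition), compound 1 gives 5000 nM. Compound 2 `COc1cc2c(cc1OC)C(=O)/C(=C/c1cccc(OC)c1OC)CC2` reaches only a limit of the assay, > 50000 nM. The pair of values shown thus includes (the limit of > 50000 nM in this assay, at which 1 of the 2 values shown sits). For the measured compounds named here, the sole measured step, an at least 10-fold higher number from compound 1 to compound 2 (1.00 log units; beyond the scatter), comes from putting methoxy in place of hydrogen on an aromatic carbon. Compound 3 `COc1cc2c(cc1OC)C(=O)/C(=C/c1cc(Cl)cc(Cl)c1)CC2` arises from compound 1 by a different change, (3,5-dichlorophenyl in place of 3-methoxyphenyl on a double-bonded chain carbon bound to a double-bonded ring carbon). Going by the values given here, no measured step touches an exchange of this kind, so the one step on record gives no guidance on size or direction, and the expectation rests on the value of compound 1 alone. Relative to compound 1, compound 3 is expected to shift by a 1.3-fold lower number from compound 1 to compound 3 (0.10 log units; within the scatter). Compound 3 is therefore estimated at 4000 nM, with a range from 800 nM to 20000 nM.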

Compound 3, half-maximal inhibitory concentration: 7000 nM
Beside the measured number, compound 3's estimate is 1.8-fold (0.24 log units) below it; measured number inside the range.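

In this assay, exchanging 3-methoxyphenyl for 3,5-dichlorophenyl on a double-bonded chain carbon bound to a double-bonded ring carbon gives a 1.4-fold higher number from compound 1 to compound 3 (0.15 log units; within the scatter), so this position accepts a quite different pair of ring substituents with no change that stands clear of the scatter. Among the compounds shown here, the one earlier step, an at least 10-fold higher number from compound 1 to compound 2 (1.00 log units; beyond the scatter), showed a single added methoxy costing activity at this ring, and the new step shows that not every change here does so. Nothing shown offers a measured property that would account for this result.

The compounds shown leave open how a plain phenyl, or a ring bearing an amine or a carboxylic acid, would read at this place. They also leave open what the two methoxy groups of the shared core contribute, as every compound shown carries them.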